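The source may hold more compounds than are shown below. What is called first, only, known or untested is meant among the compounds shown, and "the series" means these compounds.

Series notes. Compound 1 `O=C(OCc1ccccc1)c1cc(-c2ccc(Cl)cc2)nc2cc(Cl)c(Cl)cc12` and compound 2 `COc1ccc(-c2cc(C(=O)OCc3ccccc3)c3cc(Cl)c(Cl)cc3n2)cc1` share one core; compound 3 `Clc1ccc(-c2cc(COCc3ccccc3)c3cc(Cl)c(Cl)cc3n2)cc1` and compound 4 `COc1ccc(-c2cc(COCc3ccccc3)c3cc(Cl)c(Cl)cc3n2)cc1` share another, and the difference between the two cores is not broken down here. Compound 2 differs from compound 1 by methoxy in place of chloro on an aromatic carbon. In a functional assay on MDA-MB-231 cells (Homo sapiens) for antiproliferative activity, read by MTT assay, with a stated time of 48 h (a lower number here means a stronger inhibitor, a higher number a weaker inhibitor), compound 1 gives only a limit, > 100000 nM. Compound 2 gives 39200 nM in this assay, so the change made an at least 2.5-fold lower number from compound 1 to compound 2 (0.40 log units; beyond the scatter). The size of that step can be given only as a minimum because of the limit of > 100000 nM in this assay, at which 2 of the 3 values shown sit. In this assay compound 3 likewise gives only a limit, > 100000 nM. Compound 4 differs from compound 3 by methoxy in place of chloro on an aromatic carbon, the same change on the same kind of position as from compound 1 to compound 2. For compound 4 in this assay the expectation is an at least 1.6-fold lower number from compound 3 to compound 4 (0.22 log units; that floor lies within the scatter), resting on the step of an at least 2.5-fold lower number from compound 1 to compound 2 (0.40 log units; beyond the scatter) seen on the other core, with the caveat that compound 3 itself is known only as a limit. Compound 4 is thus estimated at 60000 nM in this assay, between 20000 nM and 200000 nM, with a real chance that this assay again returns only a limit.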

Compound 4, half-maximal inhibitory concentration: > 100000 nM
Compound 4: a limit, no number (the forecaster's own chance of this, stated with the estimate: 45%); middle value at least 1.6-fold (0.22 log units) away from the limit.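

In this assay compound 4 gives > 100000 nM, which is a limit and not a number. The step from 4-chlorophenyl to 4-methoxyphenyl cannot be read on the core of compound 3, so the change seen on the other core, an at least 2.5-fold lower number from compound 1 to compound 2 (0.40 log units; beyond the scatter), is neither confirmed nor contradicted there, because both compounds on this core give only a limit: the limit of > 100000 nM in this assay, at which 3 of the 4 values shown sit. With 4-methoxyphenyl held constant, (benzyloxy)methyl in place of benzyloxycarbonyl gives an at least 2.5-fold higher number from compound 2 to compound 4 (0.40 log units; beyond the scatter), so compound 2 remains the only compound shown with a measured number, and the methoxy step is supported on one core only.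

As far as these compounds go, it remains open whether an amine or a hydroxyl in place of chloro on the same aromatic carbon would lower the number as methoxy does on the core of compound 1. Also open, from the compounds shown here alone, is how an amide or a carboxylic acid in place of benzyloxycarbonyl would read in this assay.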